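This account rests on a few compounds, and the source may have more. Where it says the series, first, only, none or still open, it means among the compounds named here.

Compound 1 `COc1ccccc1N1CCN(CC(=O)N2CCN(c3nnc(-c4ccc(C)cc4)c(-c4ccc(C)cc4)n3)CC2)CC1` gives 133000 nM in an ADME assay on NIH3T3 cells (Mus musculus) for cytotoxicity, read by MTT assay, with a stated time of 24 h; a lower number here means a stronger inhibitor, a higher number a weaker inhibitor.
Compound 2 `COc1cccc(N2CCN(CC(=O)N3CCN(c4nnc(-c5ccc(C)cc5)c(-c5ccc(C)cc5)n4)CC3)CC2)c1` gives in this assay only a limit of the assay, > 866000 nM.

In this assay compound 2 stands not at a measured number but at a limit of the assay, the weak end of what was seen. Among the measured compounds shown here, the one measured step that touches it, an at least 6.5-fold higher number from compound 1 to compound 2 (0.81 log units; beyond the scatter), moved the number upward, toward weaker inhibition, and its size is known only as a bound because it rests on (the limit of > 866000 nM in this assay, at which 1 of the 2 values shown sits).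

Compound 3 `COc1ccc(N2CCN(CC(=O)N3CCN(c4nnc(-c5ccc(C)cc5)c(-c5ccc(C)cc5)n4)CC3)CC2)cc1` differs from compound 2 in one place: 4-methoxyphenyl in place of 3-methoxyphenyl on an amine nitrogen in a ring. For the measured compounds named here, no measured step compares a 3-methoxyphenyl with a 4-methoxyphenyl; the only step available shows that moving the methoxy group on this phenyl ring once weakened inhibition to the limit. With compound 2 already at the limit, compound 3 is expected to stay near it, with no step beyond the scatter in this assay. The step of an at least 1.0-fold lower number from compound 2 to compound 3 (0.03 log units; that floor lies within the scatter) is the expected change. Compound 3 is estimated at 800000 nM, within 200000 nM to 3000000 nM, with a fair chance that only a limit is reported.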

Compound 3, half-maximal inhibitory concentration: 116000 nM
Beside the measured number, compound 3's estimate is 6.9-fold (0.84 log units) above it, outside the stated range (below it).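

In this assay, the place of the methoxy group on this phenyl ring matters in a way the first step could not show: the weak result belongs to the 3-methoxyphenyl alone, not to every move away from the 2-methoxyphenyl, as an at least 7.4-fold lower number from compound 2 to compound 3 (0.87 log units; beyond the scatter) brings the number back down. Compounds with the same atoms, joined differently, can therefore sit far apart here, yet a 1.1-fold lower number from compound 1 to compound 3 (0.06 log units; within the scatter) shows that the 2-methoxyphenyl and the 4-methoxyphenyl cannot be told apart in this assay, so among these three compounds only compound 2 stands out. The size of that gap is known only as a bound, since the value of compound 2 is a limit and not a number: the limit of > 866000 nM in this assay, at which 1 of the 3 values shown sits.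

The compounds shown leave open whether the gap belongs to the methoxy group itself or would appear again with a hydroxyl, a chlorine atom or an ethoxy group at the same places on the phenyl ring. They also leave open how a phenyl ring with no group on it at all would compare with these three.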